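The source may hold more compounds than are shown below. What is called first, only, known or untested is meant among the compounds shown, and "the series" means these compounds.

Measured so far:
Compound 1, `O=C(C1CCC1)N1CC(c2nc(-c3cccc(Cl)c3)no2)C1`: in an assay on HEK293 cells for negative allosteric modulation of metabotropic glutamate receptor 5 (Homo sapiens), read by FLIPR (on this read-out higher numbers stand for weaker inhibition and lower numbers for stronger inhibition), compound 1 gives 1500 nM.
Compound 2, `O=C(C1CCC(F)(F)CC1)N1CC(c2nc(-c3cccc(Cl)c3)no2)C1`: in this assay compound 2 gives > 10000 nM, which is a limit of the assay rather than a number.

Compound 2 therefore stands at the weak end of the two values shown, and only the limit is known for it; that it sits at the limit is recorded as the limit of > 10000 nM in this assay, at which 1 of the 2 values shown sits. Among the measured compounds shown here, the one measured step that bears on the next change is an at least 6.6-fold higher number from compound 1 to compound 2 (0.82 log units; beyond the scatter), where a six-membered ring on the carbonyl carbon replaced the four-membered one and inhibition fell beyond the scatter.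

Compound 3, `COC1CCN(C(=O)N2CC(c3nc(-c4cccc(Cl)c4)no3)C2)CC1`, is not yet measured. The change from compound 2 is 4-methoxypiperidin-1-yl in place of 4,4-difluorocyclohexyl on a carbonyl carbon. For the measured compounds named here, the entering group is again a six-membered ring of the same heavy-atom count, now carrying a nitrogen and a methoxy oxygen, so the only precedent is the weak value of compound 2. Since that value is itself a limit, the size of the step cannot be fixed; the expectation is that compound 3 stays weak, with an at least 1.4-fold lower number from compound 2 to compound 3 (0.15 log units; that floor lies within the scatter) as the estimated step. Compound 3 is thus expected to give about 7000 nM in this assay, within 1500 nM to 30000 nM.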

Compound 3, half-maximal inhibitory concentration: > 10000 nM
Compound 3: no number, only a limit (the forecaster's own chance of this, stated with the estimate: 50%); at least 1.4-fold (0.15 log units) between middle value and limit.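

In this assay compound 3 gives > 10000 nM, which is a limit of the assay and not a number. Putting 4-methoxypiperidin-1-yl in place of cyclobutyl on the carbonyl carbon gives an at least 6.6-fold higher number from compound 1 to compound 3 (0.82 log units; beyond the scatter), so a six-membered ring with a hetero atom and a hydrogen-bond acceptor loses inhibition beyond the scatter, as the all-carbon 4,4-difluorocyclohexyl ring did. Swapping the carbon-only ring for the one with a hetero atom does not bring a readable value back at this position, and the step between those two groups cannot be read, since both ends are limits; the weak end of the series is now shared by both six-membered groups: the limit of > 10000 nM in this assay, at which 2 of the 3 values shown sit.

The compounds shown leave open whether the loss follows the six-membered ring itself or the substituents it carries, and how far apart compound 2 and compound 3 really lie. From the compounds shown here alone, how a cyclopentyl group, a pyrrolidin-1-yl group or an unsubstituted piperidin-1-yl group would read on the same carbonyl carbon also stays open.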